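Amide nitrogen substituents on a shared nitro chromene core

The source may hold more compounds than are shown below. What is called first, only, known or untested is meant among the compounds shown, and "the series" means these compounds.

Measured compounds:
Compound 1, `CCNC(=O)C1=CC(C)(C)Oc2ccc([N+](=O)[O-])cc21`, 80.5%
Compound 2, `CCCNC(=O)C1=CC(C)(C)Oc2ccc([N+](=O)[O-])cc21`, 74.1%
Compound 3, `CC1(C)C=C(C(=O)NC2CC2)c2cc([N+](=O)[O-])ccc2O1`, 78%

In a functional assay on the whole organism (muscle tissue) with Rattus norvegicus as the target (on this read-out lower numbers stand for smaller maximal responses and higher numbers for larger maximal responses), compound 3 gives 78%. Among the three measured compounds it stands second highest, nearest to compound 1, which gives 80.5%, and furthest from compound 2, which gives 74.1%; both of these gaps are within the scatter, so no order among the three can be read from them.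

Compound 4, `C#CCNC(=O)C1=CC(C)(C)Oc2ccc([N+](=O)[O-])cc21`, has not yet been measured. It differs from compound 3 in one place: propargyl in place of cyclopropyl on an amide-type nitrogen.

Among the compounds with values here, two measured steps bear on this change, since each also swaps the group on the amide-type nitrogen. The step of a number 2.5 percentage points lower from compound 1 to compound 3 (within the scatter) and the step of a number 3.9 percentage points higher from compound 2 to compound 3 (within the scatter) were both within the scatter, and the step of a number 6.4 percentage points lower from compound 1 to compound 2 (within the scatter) likewise stayed within it. Three different groups on that nitrogen have therefore left the maximal response in this assay essentially unchanged. A fourth group of the same size is expected to behave alike, with no step beyond the scatter in either direction.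

Compound 4 is therefore estimated to give 77% in this assay, between 65% and 88%, an expected step of a number 1 percentage points lower from compound 3 to compound 4 (within the scatter).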

Compound 4, intrinsic activity: the largest response reached, in percent of the reference agonist's: 80.2%
For compound 4 the middle estimate is 3.2 percentage points below the measured one, within the range that was stated.
By their numbers in this assay, from the lowest: compounds 2, 3, 4 and 1 (each within the scatter of the next).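

Replacing cyclopropyl with propargyl on the amide-type nitrogen gives, in this assay, a number 2.2 percentage points higher from compound 3 to compound 4 (within the scatter), so giving up the three-membered ring for a triple bond, with the count of heavy atoms unchanged, leaves no readable mark on the maximal response. The open chains tell the same story, with ethynyl in place of ethyl giving a number 6.1 percentage points higher from compound 2 to compound 4 (within the scatter) and ethynyl in place of methyl giving a number 0.3 percentage points lower from compound 1 to compound 4 (within the scatter), so that among these four compounds this position has carried saturated chains, a three-membered ring and a triple bond without any step beyond the scatter, and none of the four goes against this. No measurement is at hand that could speak to why the maximal response holds across these groups.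

The compounds leave open whether this flat picture lasts with a group of another kind on that nitrogen, such as a phenyl ring, a hexyl chain, or a chain ending in an amine or a carboxylic acid. As far as these compounds go, all four also keep the amide hydrogen, so what a second group on the nitrogen, such as a methyl, would do to the maximal response remains unknown.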